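The source may report more compounds than this note shows. Statements on the series, on what has been measured and on what is new or still open speak of the compounds shown alone.

Measured compounds:
compound 1, `CN1CCN(C(=S)SCc2nc3cc(Cl)c(Cl)cc3[nH]2)CC1`, with 30500 nM;
compound 2, `c1ccc2[nH]c(SCCCN3CCNCC3)nc2c1`, with 91700 nM.

Both were tested in a functional assay on MCF7 cells (Homo sapiens) for cytotoxicity, read by MTT assay, with a stated time of 24 h; a higher number here means a weaker inhibitor, a lower number a stronger inhibitor. Compound 2 gives the higher of the two numbers, and the gap between it and compound 1 lies beyond the usual scatter, so on these two values compound 2 is the weaker inhibitor of the pair. Compound 3, `CCOc1ccccc1N1CCN(CCCSc2nc3ccccc3[nH]2)CC1`, has not yet been measured in this assay. It differs from compound 2 in one place: 2-ethoxyphenyl in place of hydrogen on an amine nitrogen in a ring.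

For the measured compounds named here, no measured pair shows what a change of this kind does here, so the expectation rests on compound 2 alone. The step from compound 2 to compound 3 is expected to be downward and beyond the scatter, a 3.1-fold lower number from compound 2 to compound 3 (0.49 log units; beyond the scatter). For compound 3 the estimate in this assay is therefore 30000 nM, with a range from 8000 nM to 100000 nM.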

Compound 3, half-maximal inhibitory concentration: 32700 nM
For compound 3 the middle estimate is 1.1-fold (0.04 log units) below the measured one; measured number inside the range.
By their numbers in this assay, from the lowest: compounds 1 and 3 (each within the scatter of the next); then compound 2.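

In this assay, the amine nitrogen in the six-membered ring with 2 nitrogen proves open to a large substituent: 2-ethoxyphenyl in place of hydrogen gives a 2.8-fold lower number from compound 2 to compound 3 (0.45 log units; beyond the scatter) and this modest step lies beyond the scatter. The hydrogen on this nitrogen is therefore not needed to keep the cytotoxic effect, and a group of 9 heavy atoms carrying a six-membered aromatic ring is accepted there with a lower number rather than a higher one. Nothing available accounts for the size or direction of this step.

On these data alone, it remains open whether a plain phenyl, a benzyl or a small methyl on the same nitrogen would move the number as far. As far as these compounds go, it is equally open whether the ethoxy group itself contributes, which a comparison with 2-methoxyphenyl or 2-hydroxyphenyl at this position could test.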